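The source may report more compounds than this note shows. Statements on the series, on what has been measured and on what is new or still open speak of the compounds shown alone.

Measured in a functional assay on the whole organism with Rattus norvegicus as the target; a lower number here means that less compound is needed, a higher number that more compound is needed for the effect:

Compound 1 `C#CCn1c(=N)sc2cc(OC(F)(F)F)ccc21`: 4 mg/kg
Compound 2 `CN(C)S(=O)(=O)CCn1c(=N)sc2cc(OC(F)(F)F)ccc21`: > 10 mg/kg (a limit of the assay)
Compound 3 `C[S+]([O-])Cn1c(=N)sc2cc(OC(F)(F)F)ccc21`: 2.3 mg/kg

Compound 3 has the lowest of the two actual numbers in this assay, but the step of a 1.7-fold lower number from compound 1 to compound 3 (0.24 log units; within the scatter) lies within the scatter, so compound 3 and compound 1 cannot be separated. The value of compound 2 is a limit and not a number. Compared with it, both other compounds sit lower, as an at least 2.5-fold higher number from compound 1 to compound 2 (0.39 log units; beyond the scatter) and an at least 4.3-fold lower number from compound 2 to compound 3 (0.63 log units; beyond the scatter) show, and both of these steps lie beyond the scatter.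

Compound 4 `C[S+]([O-])CCn1c(=N)sc2cc(OC(F)(F)F)ccc21` differs from compound 3 by a single change: a group of 4 heavy atoms (2 carbon, 1 oxygen, 1 sulfur; no ring) in place of a group of 3 heavy atoms (1 carbon, 1 oxygen, 1 sulfur; no ring), on a saturated chain carbon bound to an aromatic nitrogen. All three measured steps fall at this same place. The closest guide is a 1.7-fold lower number from compound 1 to compound 3 (0.24 log units; within the scatter), which swaps small groups and leaves the number within the scatter. The larger group of compound 2 gives a warning, seen in an at least 4.3-fold lower number from compound 2 to compound 3 (0.63 log units; beyond the scatter), but its group is much bigger than the one entering here. No step beyond the scatter is therefore expected, with only a slight lean towards a higher number. The expected change is a 1.5-fold higher number from compound 3 to compound 4 (0.18 log units; within the scatter). For compound 4 the estimated value is 3.5 mg/kg, with an expected range from 1.3 mg/kg to 9 mg/kg.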

Compound 4, dose for half-maximal effect: 1.1 mg/kg
The estimate for compound 4 lay 3.2-fold (0.50 log units) above the measured number, and the stated range ends above it.
By their numbers in this assay, from the lowest: compound 4; then compounds 3 and 1 (each within the scatter of the next). At a limit, above all of these: compound 2.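

In this assay, the group of 4 heavy atoms entering in place of the group of 3 heavy atoms gives a 2.1-fold lower number from compound 3 to compound 4 (0.32 log units; beyond the scatter), so a change this small on a saturated chain carbon bound to an aromatic nitrogen can move the number beyond the scatter, which the step between compound 1 and compound 3 did not do. The same group also separates clearly from the group of 2 heavy atoms, with a 3.6-fold lower number from compound 1 to compound 4 (0.56 log units; beyond the scatter), and compound 4 is thereby set apart from compound 3 and compound 1, which could not be told apart from each other. The step of an at least 9.0-fold lower number from compound 2 to compound 4 (0.95 log units; beyond the scatter) is larger again, but it rests on a limit of compound 2 and not on a number, so its true size stays unknown: the limit of > 10 mg/kg in this assay, at which 1 of the 4 values shown sits.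

From the compounds shown here alone, whether a longer chain carrying the same sulfur and oxygen would lower the number further stays open, as does whether an amine or a carboxylic acid at this place would come close to compound 4. All four compounds share one core, so whether this step holds on another core also remains unanswered.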